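Triazole carbamate series: cyclohexyl ester in place of benzyl carbamate

The compounds below may be only part of what the source reports. "The series", "measured", "known", "first", "only" and "open" are said of these compounds alone.

Measured so far in an assay on nucleic acid for inhibition of Nucleic Acid, read by fluorescence, tested at 100 uM; on this read-out higher numbers stand for more inhibition at the one concentration tested (going by the name of the read-out) and lower numbers for less inhibition:
compound 1 `CCCCN(CCCC)Cc1cn(CC(O)COC(=O)NCc2ccccc2)nn1`, 42%
compound 2 `CN(Cc1cn(CC(O)COC(=O)NCc2ccccc2)nn1)CC1CCCCC1`, 32%

Two compounds share the core with the benzyl carbamate arm. Compound 1 gives 42%; compound 2 gives 32%. Within the data shown here, the only step between them, a number 10 percentage points lower from compound 1 to compound 2 (within the scatter), swaps the amine on the saturated chain carbon bound to an aromatic carbon and stays within the scatter, so compound 1 and compound 2 cannot be ordered on these numbers.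

Compound 3 `CCCCN(CCCC)Cc1cn(CC(O)COC(=O)C2CCCCC2)nn1` keeps the dibutylamino of compound 1 and alters the other end: cyclohexyl in place of benzylamino on a carbonyl carbon. Among the measured compounds shown here, no measured step touches the carbonyl end of the molecule; the single step in hand concerns the amine and is of no use for this change. The hydrogen-bond donor counted in the leaving group is lost, but nothing measured shows what that costs or gains. The expectation for this assay is therefore unanchored and carries a wide range.

Compound 3 is expected at 35%, between 10% and 60%, which is an expected step of a number 7 percentage points lower from compound 1 to compound 3 (within the scatter).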

Compound 3, a percentage reported as inhibition, at one concentration (the size of the read-out at that concentration, not a potency): 12%
The estimate for compound 3 lay 23 percentage points above the measured number; the measured number falls inside the stated range.
By their numbers in this assay, from the lowest: compound 3; then compounds 2 and 1 (each within the scatter of the next).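

In this assay, among these compounds, the carbonyl end of the molecule now carries a measured step, and it is the first step to lie beyond the scatter: a number 30 percentage points lower from compound 1 to compound 3 (beyond the scatter). Cyclohexyl in place of benzylamino on a carbonyl carbon is therefore not a neutral exchange with the dibutylamino group held constant, whereas the earlier step at the amine could not order its two compounds. Among the compounds shown here, no available evidence accounts for this drop, and the exchange alters the ring type, the nitrogen and the hydrogen-bond donor of benzylamino all at once, so the single step cannot assign it to any one of them.

The compounds shown leave open which of these differences carries the step; cyclohexylamino on the carbonyl carbon would keep the nitrogen and the non-aromatic ring, while benzyl there would keep the aromatic ring without the nitrogen. They also leave open whether the same exchange gives a similar step when (cyclohexylmethyl)(methyl)amino replaces dibutylamino on the other end of the molecule.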